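Swapping fluorine for chlorine on a weakly active compound

A few compounds are considered here, and "the series" means these few. Any claim that something is new, unique, unknown or untested is made for them only; others in the source may bear on it.

Compound 1 `Cc1n[nH]c2ccc(-c3nc4cnc(N5CCN(C)CC5)cn4c3Nc3ccccc3F)cc12` and compound 2 `Cc1n[nH]c2ccc(-c3nc4cnc(N5CCN(C)CC5)cn4c3Nc3ccc(F)cc3)cc12` share one core and differ only in where a single fluorine sits on the aniline ring. In a functional assay on MV4-11 cells (Homo sapiens) for inhibition, with a stated time of 120 h (on this read-out lower numbers stand for stronger inhibition and higher numbers for weaker inhibition), compound 1 gives "not determined" (no result reported), so no number was reported for it. In this assay, among the compounds with values here, compound 2 gives 32300 nM, the only value on hand, a weak result. Compound 3 `Cc1n[nH]c2ccc(-c3nc4cnc(N5CCN(C)CC5)cn4c3Nc3ccc(Cl)cc3)cc12` carries chloro in place of fluoro on an aromatic carbon. Within the data shown here, with no comparable step available, the change from compound 2 to compound 3 is expected to be small, a 1.3-fold lower number from compound 2 to compound 3 (0.11 log units; within the scatter), within the usual scatter or slightly stronger. Compound 3 is therefore estimated at 25000 nM, plausibly between 10000 nM and 60000 nM.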

Compound 3, half-maximal inhibitory concentration: 3510 nM
Beside the measured number, compound 3's estimate is 7.1-fold (0.85 log units) above it, and the stated range ends above it.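

Swapping one halogen for another at this place, para to a large group, is enough to matter: the 4-fluorophenyl to 4-chlorophenyl change gives a 9.2-fold lower number from compound 2 to compound 3 (0.96 log units; beyond the scatter) in this assay. The position is therefore sensitive to which atom it carries, even though the count of heavy atoms stays the same. Nothing on hand gives a reason for this difference.

On these data alone, whether bromo, methyl or an amine at this place would lower the number further remains open. Compound 1 has no number, so the effect of moving the halogen around the ring cannot be read.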